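This account rests on a few compounds, and the source may have more. Where it says the series, first, only, none or still open, it means among the compounds named here.

Measured compounds:
Compound 1 `CC(C)(C)c1ncc(C#Cc2ccccc2)cn1`: 247000 nM
Compound 2 `CNc1ncc(C#Cc2ccc(C)cc2)cn1`: 704000 nM

In an assay on HEK293 cells for positive allosteric modulation of metabotropic glutamate receptor 5 (Rattus norvegicus) (a higher number here means that more compound is needed for the effect, a lower number that less compound is needed), compound 1 gives 247000 nM, while compound 2 gives 704000 nM. Compound 2 therefore stands at the highest of the two numbers; its nearest neighbour is compound 1, and the gap between the two lies beyond the scatter. Compound 3 `COc1ncc(C#Cc2ccc(C)cc2)cn1` has not yet been measured in this assay. It differs from compound 2 in one place only: methoxy in place of methylamino on an aromatic carbon. Within the data shown here, no measured pair in this set shows what this particular exchange does, so nothing from the data points to a direction. The step from compound 2 to compound 3 in this assay is therefore expected to be a 1.2-fold lower number from compound 2 to compound 3 (0.07 log units; within the scatter), that is, none beyond the scatter. For compound 3 the estimate in this assay is 600000 nM, with a range from 200000 nM to 2000000 nM.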

Compound 3, half-maximal effective concentration: "not active" (no number reported)
No number was reported for compound 3; there is nothing to compare the estimate with.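

Among these compounds, compound 3 was reported as "not active" in this assay, without a number, so no step from compound 2 to compound 3 can be read. The compounds shown leave open how far methoxy in place of methylamino shifts the number, and no available evidence bears on this result.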